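Extending the ether chain from compound 3 to compound 4

The source may report more compounds than this note shows. Statements on the series, on what has been measured and on what is new or still open speak of the compounds shown alone.

Measured so far in an assay (strain Wistar) for binding affinity to Neuronal acetylcholine receptor; alpha4/beta2 (Rattus norvegicus); on this read-out higher numbers stand for weaker inhibition and lower numbers for stronger inhibition:
compound 1, `Clc1ncc(N2CCCNCC2)cc1Br`: 1.4 nM
compound 2, `COc1cncc(N2C3CCNCC2CC3)c1`: 10 nM
compound 3, `COc1cncc(N2CCCNCCC2)c1`: 1 nM

Compound 3 gives the lowest of the three numbers in this assay. Its nearest neighbour is compound 1, whose number is higher by a margin that lies within the scatter, so no order between these two can be read. Compound 2 stands furthest away, beyond the scatter, and is the weakest of the three on this read-out.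

Compound 4, `CCCCOc1cncc(N2CCCNCCC2)c1`, differs from compound 3 by propyl in place of hydrogen on a saturated chain carbon bound to an oxygen on an aromatic ring; cut one bond further out, the change reads methoxy to butoxy. Within the data shown here, no measured pair in the set shows this change, so the size of the step has no anchor among the numbers in hand. The expectation is a moderate loss of affinity in this assay, with the step estimated at a 5.0-fold higher number from compound 3 to compound 4 (0.70 log units; beyond the scatter), and a gain beyond the scatter is taken as unlikely. Compound 4 is therefore expected to give 5 nM in this assay, within a range from 1 nM to 25 nM.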

Compound 4, half-maximal inhibitory concentration: 1.8 nM
The estimate for compound 4 lay 2.8-fold (0.44 log units) above the measured number; the measured number falls inside the stated range.
By their numbers in this assay, from the lowest: compounds 3, 1 and 4 (each within the scatter of the next); then compound 2.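

Methoxy to butoxy on the shared core gives a 1.8-fold higher number from compound 3 to compound 4 (0.26 log units; within the scatter) in this assay, so no order between these two compounds can be read. Among these compounds, this is the first pair that differs in one place, and it shows that propyl in place of hydrogen on a saturated chain carbon bound to an oxygen on an aromatic ring leaves no readable change on this read-out. Nothing available explains this result.

On these data alone, whether the same holds for a longer chain such as hexyloxy, for a chain ending in an amine or a carboxylic acid, or for a ring such as phenyl on that carbon remains open. This single pair also says nothing about the same change on the cores of compound 1 and compound 2.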